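A few compounds are considered here, and "the series" means these few. Any claim that something is new, unique, unknown or untested is made for them only; others in the source may bear on it.

Compound 1 `Cc1ccccc1N1CCN(C(=O)CN2C(=O)CC(C)C2=O)CC1` was tested in a functional assay on the whole organism (strain CD1) with Mus musculus as the target, with a stated time of 0.5 h (on this read-out higher numbers stand for an effect only at larger amounts of compound and lower numbers for an effect already at smaller amounts), where compound 1 gives 100 mg/kg. Compound 2 `CCC1(C)CC(=O)N(CC(=O)N2CCN(c3ccccc3C)CC2)C1=O` differs from it only by ethyl in place of hydrogen on a saturated ring carbon; in this assay compound 2 gives 100 mg/kg, and no change at the digits printed from compound 1 to compound 2 (within the scatter). Compound 3 `CC1CC(=O)N(CC(=O)N2CCN(c3cccc(C(F)(F)F)c3)CC2)C1=O` carries a different substituent on its aromatic ring, and in this assay compound 3 gives 300 mg/kg. On these numbers compound 1 stands level with compound 2, the two together being the lowest of the three, while compound 3 lies furthest from compound 1, beyond the scatter.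

Compound 4 `CC1CC(=O)N(CC(=O)N2CCN(c3ccccc3Cl)CC2)C1=O` is the next step from compound 1: chloro in place of methyl on an aromatic carbon. Going by the values given here, no measured step swaps one group for another on the aromatic ring. Among the compounds with values here, the only measured step touches a saturated ring carbon and stays within the scatter, and compound 3 shows only that another aromatic substituent can move the number beyond the scatter. With nothing measured speaking directly to this change, the expected step in this assay is no change at the digits printed from compound 1 to compound 4 (within the scatter), nothing beyond the scatter. In this assay compound 4 is therefore estimated to give 100 mg/kg, within a range from 50 mg/kg to 300 mg/kg.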

Compound 4, minimum effective dose: 300 mg/kg
Compound 4: middle estimate off by 3.0-fold (0.48 log units), on the low side; the measured number falls inside the stated range.
By their numbers in this assay, from the lowest: compounds 1 and 2 (each within the scatter of the next); then compounds 3 and 4 (each within the scatter of the next).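

Going by these compounds alone, this is the first measured change at this position on the aromatic ring: in this assay, going from 2-methylphenyl to 2-chlorophenyl gives a 3.0-fold higher number from compound 1 to compound 4 (0.48 log units; beyond the scatter), a modest step. Within the data shown here, the only earlier step touched a saturated ring carbon and stayed within the scatter, so this result is the first to show that exchanging methyl for chloro alone, ortho to a large group, can shift the read-out beyond the scatter. Nothing available explains why these two groups differ here.

From the compounds shown here alone, it remains open whether other groups at this position, such as methoxy, fluoro or an amine, would match compound 1 or compound 4. Also open, going by these compounds, is whether the same exchange would produce a similar step on compound 2, which carries the ethyl group.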